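Changing one aromatic group on compound 2

The source may hold more compounds than are shown below. What is called first, only, known or untested is meant among the compounds shown, and "the series" means these compounds.

Of the compounds shown here, three with a shared core have been tested in a functional assay on HepG2 cells (Homo sapiens) for antiproliferative activity, read by spectrophotometry, with a stated time of 2 days; a lower number here means a stronger inhibitor of growth, a higher number a weaker inhibitor of growth. Compound 1 (`COc1cc(N2CCN(C(C)=O)CC2)ccc1Nc1ncc(C(F)(F)F)c(N2Cc3cccc(N(C)S(C)(=O)=O)c3C2)n1`) gives 3800 nM, and compound 3 (`CN(c1cccc2c1CN(c1nc(Nc3cccc(Oc4ccccc4)c3)ncc1C(F)(F)F)C2)S(C)(=O)=O`) gives 23000 nM. Compound 2 (`Cc1ccc(Nc2ncc(C(F)(F)F)c(N3Cc4cccc(N(C)S(C)(=O)=O)c4C3)n2)c(Cl)c1`) gives > 30000 nM, which is a limit of the assay and not a number. On these data alone, compound 2 therefore sits at the limit of > 30000 nM in this assay, at which 1 of the 3 values shown sits, and its exact position remains unknown.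

Compound 4 (`CN(c1cccc2c1CN(c1nc(Nc3ccc(C(F)(F)F)cc3)ncc1C(F)(F)F)C2)S(C)(=O)=O`) has not yet been measured. It differs from compound 2 by one change, 4-(trifluoromethyl)phenyl in place of 2-chloro-4-methylphenyl on a nitrogen on an aromatic ring. Among the measured compounds shown here, no measured pair shows the effect of such a swap directly. The nearest guide is compound 3, which carries another aromatic group on that nitrogen and gives 23000 nM. A small gain in growth inhibition is therefore expected, an estimated at least 1.5-fold lower number from compound 2 to compound 4 (0.17 log units; that floor lies within the scatter), and another reading at the limit is quite possible. For compound 4 the expected value is 20000 nM, with an estimated range from 8000 nM to 30000 nM.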

Compound 4, concentration for 50% growth inhibition: > 30000 nM
Compound 4 ended at the assay's limit; the forecaster's own chance of this, stated with the estimate: 40%; middle value at least 1.5-fold (0.17 log units) from the limit.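

In this assay, compound 2 and compound 4 both end at a limit of the assay and not at a number, so no step between them can be read: the limit of > 30000 nM in this assay, at which 2 of the 4 values shown sit.

The compounds shown leave open whether 4-(trifluoromethyl)phenyl in place of 2-chloro-4-methylphenyl changes growth inhibition at all, and by how much.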